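Azole swap at the aryl amide series: compound 3 to compound 4

The source may report more compounds than this note shows. Statements on the series, on what has been measured and on what is new or still open speak of the compounds shown alone.

Three azole-bearing analogues of one aryl amide have been measured in a functional assay on the whole organism (COLO 205 cells) for inhibition, with Mus musculus as the target, read by polymerase chain reaction, in a xenograft, with a stated time of 8 h, at a dose of 40 mg/kg by the oral route; on this read-out higher numbers stand for more inhibition at the one dose given (going by the name of the read-out) and lower numbers for less inhibition. Compound 1 `Cc1cc(C)c(-c2ncc[nH]2)cc1NC(=O)c1ccc(OCc2ccccn2)cc1` gives 88%, compound 2 `Cc1cc(C)c(-c2cn(C)cn2)cc1NC(=O)c1ccc(OCc2ccccn2)cc1` gives 87%, and compound 3 `Cc1ncc(-c2cc(NC(=O)c3ccc(OCc4ccccn4)cc3)c(C)cc2C)[nH]1` gives 81%. Going by the values given here, compound 3 stands alongside the other two: the steps of a number 7 percentage points lower from compound 1 to compound 3 (within the scatter) and a number 6 percentage points lower from compound 2 to compound 3 (within the scatter) are both within the scatter, as is a number 1 percentage points lower from compound 1 to compound 2 (within the scatter), so no compound of the three is separated from another.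

Compound 4 `Cc1cc(C)c(-c2c[nH]nc2C)cc1NC(=O)c1ccc(OCc2ccccn2)cc1` differs from compound 3 as follows: 3-methyl-1H-pyrazol-4-yl in place of 2-methyl-1H-imidazol-5-yl on an aromatic carbon. The change is again an exchange of one five-membered aromatic ring for another at the same carbon of the shared core, which is exactly the kind of change covered by the three measured steps. None of those steps moved the read-out beyond the scatter, and compound 3 itself gives 81% after such a change from compound 1. The expected step is therefore a number 1 percentage points higher from compound 3 to compound 4 (within the scatter), that is, none beyond the scatter in this assay. Compound 4 is estimated at 82%, expected to fall between 66% and 94%, with the width reflecting the scatter of single-dose measurements in this assay.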

Compound 4, a percentage reported as inhibition, in the whole organism at one dose (the size of the read-out at that dose, not a potency): 75%
Compound 4: the middle estimate sits 7 percentage points above what was measured; measured number inside the range.
By their numbers in this assay, from the lowest: compounds 4, 3, 2 and 1 (each within the scatter of the next, the first and the last beyond it).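

In this assay, going by these compounds alone, the move to 3-methyl-1H-pyrazol-4-yl on this aromatic carbon, ortho to a methyl group and para to a methyl group, gives steps beyond the scatter, which no step among the earlier compounds did: a number 12 percentage points lower from compound 2 to compound 4 (beyond the scatter) and a number 13 percentage points lower from compound 1 to compound 4 (beyond the scatter) show that the choice of five-membered aromatic ring at this place can separate compounds, though only modestly, while a number 6 percentage points lower from compound 3 to compound 4 (within the scatter) leaves compound 3 unseparated from compound 4. The leaving 2-methyl-1H-imidazol-5-yl and the entering 3-methyl-1H-pyrazol-4-yl have the same heavy atoms and the same hydrogen-bond donor and acceptor counts, so these counts do not tell that pair apart, and the two compounds are simply the same atoms joined differently. Nothing at hand bears on why the read-out differs between these rings.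

Every group shown at this carbon is a five-membered aromatic ring with two ring nitrogens, so the read-out with a carboxylic acid or a simple amine at the same place remains open. Also open, as far as these compounds go, is whether the separation of compound 4 from compound 1 and compound 2 would hold at other doses, as each number here is the size of the read-out at one dose and not a potency.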